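This account rests on a few compounds, and the source may have more. Where it says the series, first, only, none or still open, it means among the compounds named here.

In a functional assay on MIA PaCa-2 cells (Homo sapiens) for antiproliferative activity, read by MTT assay, with a stated time of 24 h (on this read-out higher numbers stand for weaker inhibition and lower numbers for stronger inhibition), compound 1 `COc1ccc(-c2noc(-c3ccccc3)n2)cc1OC1CCCC1` gives only an assay limit, > 1000000 nM. Compound 3 `COc1cc(-c2noc(-c3ccncc3)n2)ccc1OCc1ccccc1` likewise reaches only a limit, > 1000000 nM, in this assay. Among the measured compounds shown here, compound 2 `COc1ccc(-c2noc(-c3ccc(F)cc3)n2)cc1O` is the one member of the set with an actual number in this assay, 351000 nM. Compound 1 thus stands at the limit of > 1000000 nM in this assay, at which 2 of the 3 values shown sit, with no number of its own. Compound 4 `COc1ccc(-c2noc(-c3ccc(Cl)cc3)n2)cc1OC1CCCC1` differs from compound 1 by chloro in place of hydrogen on an aromatic carbon. For the measured compounds named here, no measured pair shows what such a change does here. In this assay the expected step is an at least 1.2-fold lower number from compound 1 to compound 4 (0.09 log units; that floor lies within the scatter), small and with no direction beyond the scatter. Compound 4 is therefore estimated at 800000 nM, within a range from 200000 nM to 3000000 nM.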

Compound 4, half-maximal inhibitory concentration: 740 nM
The estimate for compound 4 lay 1100-fold (3.03 log units) above the measured number, outside the stated range (below it).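

In this assay, chloro in place of hydrogen on an aromatic carbon, para to a large group, gives an at least 1300-fold lower number from compound 1 to compound 4 (3.13 log units; beyond the scatter). Among the compounds shown here, this is the first measured change at this position, and it shows that this single replacement, phenyl to 4-chlorophenyl, is enough to separate compound 4 from the limit. Compound 1 has no number of its own, only a limit: the limit of > 1000000 nM in this assay, at which 2 of the 4 values shown sit.

On these data alone, whether bromo, a methoxy group or an amine at the same place would act like chloro stays open. So does whether the step would hold on a different core.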